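The compounds below may be only part of what the source reports. "The series", "measured", "known", "first", "only" and "open" are said of these compounds alone.

Measured in an ADME assay on microsomes from liver (Canis lupus familiaris) for metabolic stability; on this read-out higher numbers stand for a longer-lived compound and lower numbers for a shorter-lived compound:
- compound 1 `Nc1nc(NCCNc2ncc(-c3ncc[nH]3)c(-c3ccc(Cl)cc3)n2)ccc1[N+](=O)[O-]`: > 0.5 h
- compound 2 `Nc1nc(NCCNc2ncc(-c3ncc[nH]3)c(-c3cc(F)c(F)cc3F)n2)ccc1[N+](=O)[O-]`: > 0.5 h
- compound 3 `Nc1nc(NCCNc2ncc(-c3ncc[nH]3)c(-c3cc(F)ccc3Cl)n2)ccc1[N+](=O)[O-]`: > 0.5 h

Compound 3 stands at a limit and not at a number, and so do the other two compounds, as the limit of > 0.5 h in this assay, at which 3 of the 3 values shown sit, shows. Compound 4 `Nc1nc(NCCNc2ncc(-c3ncc[nH]3)c(-c3ccc(F)cc3Cl)n2)ccc1[N+](=O)[O-]` has not yet been measured. It has the same atoms as compound 3, joined differently, with 2-chloro-4-fluorophenyl in place of 2-chloro-5-fluorophenyl on an aromatic carbon.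

Among the compounds with values here, three measured steps bear on this change: a step that the two limits leave unreadable from compound 1 to compound 3, a step that the two limits leave unreadable from compound 2 to compound 3 and a step that the two limits leave unreadable from compound 1 to compound 2. None of them gives a size. The only anchor is the limit of compound 3, > 0.5 h. With no readable size to carry over, no change beyond the usual scatter is expected in this assay, and the expected step is a step that the limit leaves unreadable from compound 3 to compound 4. The reading may well come back as a limit again. For compound 4 the estimated half-life is 0.8 h, with an expected range of 0.5 h to 1.6 h.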

Compound 4, half-life: > 0.5 h
Compound 4 gave a limit, no number; the forecaster's own chance of this, stated with the estimate: 85%; the middle value lies beyond the limit too.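

In this assay compound 4 also gave only a limit, so its steps from compound 1, compound 2 and compound 3 cannot be read: the limit of > 0.5 h in this assay, at which 4 of the 4 values shown sit. The compounds shown leave open how long each one actually lasts, and whether swapping these phenyl groups alters that at all.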